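The source may report more compounds than this note shows. Statements on the series, on what has been measured and on what is new or still open speak of the compounds shown alone.

Measured compounds:
compound 1 `N/N=C/c1c(N)ncnc1Oc1ccc(NC(=O)C2(C(=O)Nc3ccc(F)cc3)CC2)cc1F`, 2.25
compound 2 `Nc1ncnc(Oc2ccc(NC(=O)C3(C(=O)Nc4ccc(F)cc4)CC3)cc2F)c1/C=N/O`, 2.62
compound 3 `CC(C)(C)OC(=O)N/N=C/c1c(N)ncnc1Oc1ccc(NC(=O)C2(C(=O)Nc3ccc(F)cc3)CC2)cc1F`, 3.7

In a physicochemical assay for lipophilicity, using the shake flask method (a lower number here means a more polar compound, a higher number a more lipophilic compound), compound 3 stands highest of the three. The step of a number 1.45 log units higher from compound 1 to compound 3 (beyond the scatter) and the step of a number 1.08 log units higher from compound 2 to compound 3 (beyond the scatter) both place it well apart from the other two, while the step of a number 0.37 log units higher from compound 1 to compound 2 (beyond the scatter) is a smaller one between the two lower compounds. Compound 4 `Nc1ncnc(Oc2ccc(NC(=O)C3(C(=O)Nc4ccc(F)cc4)CC3)cc2F)c1/C=N/OCCCN1CCCC1` differs from compound 3 in one place: 3-(pyrrolidin-1-yl)propoxy in place of (tert-butoxycarbonyl)amino on a double-bonded nitrogen. Among the measured compounds shown here, no measured step involves the entering group, so the only guidance comes from the two steps that end at compound 3, both large and both upward when the (tert-butoxycarbonyl)amino group enters. Since that group leaves in compound 4, a step downward in this assay, beyond the scatter, is expected, with the incoming group left unaccounted for by any measured pair. The estimate for compound 4 is therefore 2.5, with a range from 1.6 to 3.4. This expected value means a step of a number 1.20 log units lower from compound 3 to compound 4 (beyond the scatter).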

Compound 4, partition coefficient: 3.82
Compound 4: the middle estimate sits 1.32 log units below what was measured; measured number outside the range, above it.
By their numbers in this assay, from the lowest: compound 1; then compound 2; then compounds 3 and 4 (each within the scatter of the next).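

At this place on a double-bonded nitrogen, the step is a number 0.12 log units higher from compound 3 to compound 4 (within the scatter) in this assay, so 3-(pyrrolidin-1-yl)propoxy and (tert-butoxycarbonyl)amino read alike even though only the entering group carries a five-membered non-aromatic ring. The high reading is therefore not confined to (tert-butoxycarbonyl)amino: 3-(pyrrolidin-1-yl)propyl in place of hydrogen on the oxygen gives a number 1.20 log units higher from compound 2 to compound 4 (beyond the scatter) and the change from amino to 3-(pyrrolidin-1-yl)propoxy gives a number 1.57 log units higher from compound 1 to compound 4 (beyond the scatter) in the same assay. Nothing in the data accounts for these two different groups reading alike.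

The compounds shown leave open how much of the large rise belongs to the propyl chain and how much to the pyrrolidine ring. Also open, on these data alone, is whether a shorter ethyl chain, or a piperidine or morpholine ring at the chain end, would read the same.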